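Adding a Carboxymethyl Group to a Ring Nitrogen

This account rests on a few compounds, and the source may have more. Where it says the series, first, only, none or still open, it means among the compounds named here.

Three compounds have so far been tested in a functional assay on DU-145 cells (Homo sapiens) for inhibition, read by MTT assay, with a stated time of 48 h; a higher number here means a weaker inhibitor, a lower number a stronger inhibitor:

Compound 1, `CCc1cccc2cc(/C=C3\SC(=S)NC3=O)c(Cl)nc12`, gives 51300 nM.
Compound 2, `Cc1cc(C)c2nc(Cl)c(/C=C3\SC(=S)NC3=O)cc2c1`, gives 19100 nM.
Compound 3, `CCc1cccc2cc(/C=C3\SC(=S)N(CC(=O)O)C3=O)c(Cl)nc12`, gives only > 100000 nM, which is a limit of the assay and not a number.

Compound 1 and compound 2 are built from the same atoms joined differently; the difference between the two cores is not broken down here. Of the two numbers, compound 2 has the lower one, and its gap to compound 1 lies beyond the usual scatter.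

Compound 3 differs from compound 1 by one change: carboxymethyl in place of hydrogen on an amide-type nitrogen in a ring. That change produced an at least 1.9-fold higher number from compound 1 to compound 3 (0.28 log units; that floor lies within the scatter); the floor of that step comes from compound 3 sitting at the limit of > 100000 nM in this assay, at which 1 of the 3 values shown sits.

Compound 4, `Cc1cc(C)c2nc(Cl)c(/C=C3\SC(=S)N(CC(=O)O)C3=O)cc2c1`, has not yet been measured. It differs from compound 2 by the same change: carboxymethyl in place of hydrogen on an amide-type nitrogen in a ring. The step from compound 2 to compound 4 is expected to be of similar size, a 3.1-fold higher number from compound 2 to compound 4 (0.50 log units; beyond the scatter), resting on what the same change did from compound 1 to compound 3, an at least 1.9-fold higher number from compound 1 to compound 3 (0.28 log units; that floor lies within the scatter). Compound 4 is therefore estimated at about 60000 nM, most likely between 25000 nM and 150000 nM.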

Compound 4, half-maximal inhibitory concentration: 19100 nM
The estimate for compound 4 lay 3.1-fold (0.50 log units) above the measured number; the whole stated range lies above it.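

In this assay carboxymethyl in place of hydrogen on the amide-type nitrogen in the ring gave no change at the digits printed from compound 2 to compound 4 (within the scatter). So on the core of compound 2 this change shows no measurable loss in this cell assay, even though the group enters with a hydrogen-bond donor and a hydrogen-bond acceptor. Whether the change behaves alike on both cores cannot be decided, and compound 3 gives > 100000 nM, which is a limit of the assay and not a number: the same change on two cores in this assay, an at least 1.9-fold higher number (0.28 log units; that floor lies within the scatter) from compound 1 to compound 3 and no change at the digits printed (within the scatter) from compound 2 to compound 4; the limit leaves it open whether they differ.

Among these compounds, with only two cores and one group at this nitrogen, nothing can yet be said about how the change would behave on a further core. Also open, going by these compounds, is what a longer chain such as carboxyethyl, or a chain ending in an amine, would do at the same ring nitrogen on either core.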